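The compounds below may be only part of what the source reports. "The series", "measured", "known", "first", "only" and "open" are said of these compounds alone.

In a functional assay on SW-620 cells (Homo sapiens) for cytotoxicity, read by MTT assay, with stated times of 4 h and 72 h, tested at 5 uM (a lower number here means a stronger inhibitor, a higher number a weaker inhibitor), two compounds built on the same core have been measured. Compound 1 `Cc1cc(Nc2ccc(C(=O)/C=C/c3ccc4ccccc4c3)cc2)n2nc(SCc3ccc(Cl)cc3)nc2n1` gives 570 nM, and compound 2 `Cc1cc(Nc2ccc(C(=O)/C=C/c3ccc4ccccc4c3)cc2)n2nc(SCc3ccccc3C(F)(F)F)nc2n1` gives 1240 nM, the higher of the two numbers. Compound 3 `Cc1cc(Nc2ccc(C(=O)/C=C/c3ccc4ccccc4c3)cc2)n2nc(SCc3cccc(C(F)(F)F)c3)nc2n1` is still unmeasured. It differs from compound 2 in one group, with 3-(trifluoromethyl)phenyl in place of 2-(trifluoromethyl)phenyl on a saturated chain carbon bound to a sulfur. Among the compounds with values here, only one measured step bears on this change, the modest 2.2-fold higher number from compound 1 to compound 2 (0.34 log units; beyond the scatter), which replaced 4-chlorophenyl with 2-(trifluoromethyl)phenyl. Within the data shown here, no measured pair compares the two trifluoromethyl arrangements directly. Among the measured compounds shown here, a step no larger than that one is therefore expected in this assay, towards a lower number, since the only lower value belongs to compound 1 at 570 nM, which lacks the 2-(trifluoromethyl)phenyl group. The expected change is a 1.5-fold lower number from compound 2 to compound 3 (0.16 log units; within the scatter). Compound 3 is estimated at 850 nM, with an expected range of 380 nM to 1900 nM.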

Compound 3, half-maximal inhibitory concentration: 2070 nM
For compound 3 the middle estimate is 2.4-fold (0.39 log units) below the measured one; the whole stated range lies below it.
By their numbers in this assay, from the lowest: compound 1; then compounds 2 and 3 (each within the scatter of the next).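

In this assay, exchanging 2-(trifluoromethyl)phenyl for 3-(trifluoromethyl)phenyl on a saturated chain carbon bound to a sulfur gives a 1.7-fold higher number from compound 2 to compound 3 (0.22 log units; within the scatter), so this assay does not separate these two arrangements of the same atoms. The 4-chlorophenyl group of compound 1 now stands apart from both trifluoromethyl arrangements, as the exchange for 3-(trifluoromethyl)phenyl gives a 3.6-fold higher number from compound 1 to compound 3 (0.56 log units; beyond the scatter), which is a second step beyond the scatter in the same direction. No measurement is available that would explain these numbers.

Between compound 1 and the other two, both the substituent and its ring position change together, so the separate contribution of each remains open. A 4-(trifluoromethyl)phenyl or a 3-chlorophenyl group at this position would bear on that question, and an unsubstituted phenyl would give a reference for all three.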